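Removing the Acetyl from the Ring Nitrogen: Compounds 2 and 3

The compounds below may be only part of what the source reports. "The series", "measured", "known", "first", "only" and "open" are said of these compounds alone.

Measured in a functional assay on the whole organism (strain Wistar) for inhibition, with Rattus norvegicus as the target, read by paw edema, with stated times of 30 min and 120 min, at a dose of 50 mg/kg by the oral route; on this read-out higher numbers stand for more inhibition at the one dose given (going by the name of the read-out) and lower numbers for less inhibition:
Compound 1 `Cc1ccc(C2=NN(c3ccc([N+](=O)[O-])cc3)C(c3cn(-c4ccccc4)nc3-c3ccc(Cl)c(Cl)c3)C2)cc1` gives 71.9%.
Compound 2 `CC(=O)N1N=C(c2ccc(C)cc2)CC1c1cn(-c2ccccc2)nc1-c1ccc(Cl)c(Cl)c1` gives 70.3%.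

Among the measured compounds shown here, compound 2 stands alongside compound 1 within the scatter; the single step, a number 1.6 percentage points lower from compound 1 to compound 2 (within the scatter), changed the group on the ring nitrogen without a move beyond noise. Compound 3 `Cc1ccc(C2=NNC(c3cn(-c4ccccc4)nc3-c3ccc(Cl)c(Cl)c3)C2)cc1` differs from compound 2 by hydrogen in place of acetyl on an amine nitrogen in a ring. For the measured compounds named here, only that one step bears on this position, and it was flat, so no step beyond the scatter is expected in this assay, though a slight drop is allowed for. Compound 3 is therefore estimated at 63%, between 46% and 78%. The expected step is a number 7.3 percentage points lower from compound 2 to compound 3 (within the scatter).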

Compound 3, a percentage reported as inhibition, in the whole organism at one dose (the size of the read-out at that dose, not a potency): 48.4%
The estimate for compound 3 lay 14.6 percentage points above the measured number; the measured number falls inside the stated range.
By their numbers in this assay, from the lowest: compound 3; then compounds 2 and 1 (each within the scatter of the next).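

In this assay, this amine nitrogen in a ring proves sensitive to losing its group, which the flat exchange between 4-nitrophenyl and acetyl could not show. Hydrogen in place of acetyl gives a number 21.9 percentage points lower from compound 2 to compound 3 (beyond the scatter), and hydrogen in place of 4-nitrophenyl gives a number 23.5 percentage points lower from compound 1 to compound 3 (beyond the scatter). Nothing available explains this loss.

From the compounds shown here alone, it remains open whether a plain methyl, a longer chain such as propanoyl or an aminoacetyl group on this nitrogen would keep the number near compound 2 or leave it near compound 3.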